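The compounds below may be only part of what the source reports. "The series", "measured", "known", "first", "only" and "open" are said of these compounds alone.

Measured compounds:
compound 1 `Cc1cc2[nH]nc(N)c2c(=O)[nH]1`, -1%
compound 2 `CC(C)(C)c1cc2[nH]nc(N)c2c(=O)[nH]1`, -15%

In an assay on isolated protein for inhibition of serine/threonine-protein kinase D2 (Homo sapiens), read by mobility shift assay, tested at 30 uM (on this read-out lower numbers stand for less inhibition and higher numbers for more inhibition at the one concentration tested (going by the name of the read-out)), compound 1 gives -1%, the highest of the two numbers seen so far, and compound 2 gives -15%. Going by the values given here, the only measured step, a number 14 percentage points lower from compound 1 to compound 2 (beyond the scatter), comes from putting tert-butyl in place of methyl on an aromatic carbon. Compound 3 `Nc1n[nH]c2cc(CC3CCNCC3)[nH]c(=O)c12` has not yet been measured in this assay. It differs from compound 1 in one place: piperidin-4-yl in place of hydrogen on a saturated chain carbon bound to an aromatic carbon. The measured step concerns a different group at a different place, so it bears only loosely on this new change; what it does show is that both measured compounds sit close to no inhibition in this assay. For compound 3 the expected step is therefore small: a number 6 percentage points higher from compound 1 to compound 3 (within the scatter). Compound 3 is estimated at 5%, with a range from -15% to 30%.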

Compound 3, a percentage reported as inhibition, at one concentration (the size of the read-out at that concentration, not a potency): -6%
The estimate for compound 3 lay 11 percentage points above the measured number; the measured number falls inside the stated range.
By their numbers in this assay, from the lowest: compounds 2, 3 and 1 (each within the scatter of the next, the first and the last beyond it).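

Placing piperidin-4-yl on a saturated chain carbon bound to an aromatic carbon gives a number 5 percentage points lower from compound 1 to compound 3 (within the scatter) in this assay. This position can therefore carry a whole non-aromatic ring with no shift in the read-out beyond the scatter, but the ring brings no sign of inhibition at the one concentration tested: compound 3 gives -6% and stays close to no inhibition. Nothing measured on these compounds accounts for this result.

From the compounds shown here alone, whether any group at this position can produce real inhibition remains open, and a carboxylic acid, a simple primary amine or a longer chain there would help to answer that. Going by these compounds, it is also open whether a substituent on the piperidine nitrogen would change the picture.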